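A Halogen Swap on the Ester-Bearing Ring

The source may hold more compounds than are shown below. What is called first, only, known or untested is meant among the compounds shown, and "the series" means these compounds.

Three compounds share one core and differ only in the aryl group sitting on an oxygen next to a carbonyl group: compound 1 `COC(=O)c1cc(F)ccc1OC(=O)COc1cc(O)c2c(=O)cc(-c3ccccc3)oc2c1`, compound 2 `COC(=O)c1ccc(C)cc1OC(=O)COc1cc(O)c2c(=O)cc(-c3ccccc3)oc2c1` and compound 3 `COC(=O)c1ccc(Cl)cc1OC(=O)COc1cc(O)c2c(=O)cc(-c3ccccc3)oc2c1`. In a functional assay on cells (T-cell, Mus musculus, strain BALB/c) for inhibition, read by MTT assay, with a stated time of 72 h (a lower number here means a stronger inhibitor, a higher number a weaker inhibitor), compound 1 gives 6820 nM, compound 2 gives 31100 nM and compound 3 gives 12400 nM; compound 3 is the second highest of the three, close to compound 1 and farthest from compound 2. Compound 4 `COC(=O)c1c(Br)cccc1OC(=O)COc1cc(O)c2c(=O)cc(-c3ccccc3)oc2c1` differs from compound 3 in one place: a group of 11 heavy atoms (8 carbon, 2 oxygen, 1 bromine; one six-membered aromatic ring of carbon only) in place of a group of 11 heavy atoms (8 carbon, 2 oxygen, 1 chlorine; one six-membered aromatic ring of carbon only), on an oxygen next to a carbonyl group. Going by the values given here, two measured steps bear on this. a 1.8-fold higher number from compound 1 to compound 3 (0.26 log units; within the scatter) is itself a halogen swap and falls within the scatter, while a 2.5-fold lower number from compound 2 to compound 3 (0.40 log units; beyond the scatter) is modest. Another halogen swap is therefore expected to change little, and compound 4 is estimated at 10000 nM (range 4000 nM to 25000 nM), meaning a 1.2-fold lower number from compound 3 to compound 4 (0.09 log units; within the scatter).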

Compound 4, half-maximal inhibitory concentration: 41700 nM
Compound 4: middle estimate off by 4.2-fold (0.62 log units), on the low side; the measured number lies above the stated range.
By their numbers in this assay, from the lowest: compounds 1 and 3 (each within the scatter of the next); then compounds 2 and 4 (each within the scatter of the next).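

Changing the substituted aryl group on this oxygen is not always a quiet halogen swap: the bromine-bearing group gives a 3.4-fold higher number from compound 3 to compound 4 (0.53 log units; beyond the scatter) and also a 6.1-fold higher number from compound 1 to compound 4 (0.79 log units; beyond the scatter). Its result cannot be told apart from that of the methyl-bearing group, with a 1.3-fold higher number from compound 2 to compound 4 (0.13 log units; within the scatter). No measurement here explains these differences. From the compounds shown here alone, it remains open how this aryl group would behave carrying an amine or a carboxylic acid instead of a halogen or methyl.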